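The source may report more compounds than this note shows. Statements on the series, on what has been measured and on what is new or still open speak of the compounds shown alone.

Compound 1 `CCCC(=O)OCSc1ccccc1C(=O)NCCC(N)=O`: > 100 uM in an ADME assay on CEM-SS cells (Homo sapiens) for cytotoxicity, read by XTT assay, with a stated time of 6 days (on this read-out lower numbers stand for higher toxicity in this test and higher numbers for lower toxicity in this test), a limit of the assay.
Compound 2 `CCCC(=O)OCSc1ccccc1C(=O)NCCCCCCC(N)=O`: 10.4 uM in this assay.
Compound 3 `CCCC(=O)OCSc1ccccc1C(=O)N[C@H]1CCC[C@H]1C(N)=O`: 89.9 uM; 84.8 uM (2 entries) in this assay.

Compound 1 stands only at a limit of this assay, with no single number behind it; that limit is one of the three entries shown (the limit of > 100 uM in this assay, at which 1 of the 3 values shown sits). The unmeasured compound 4 `CCCC(=O)OCSc1ccccc1C(=O)NC` differs from compound 1 by hydrogen in place of carbamoylmethyl on a saturated chain carbon bound to an amide-type nitrogen. Among the compounds with values here, only one measured step touches the chain carried by the amide-type nitrogen: an at least 9.6-fold lower number from compound 1 to compound 2 (0.98 log units; beyond the scatter), where lengthening that chain brought the number down. Within the data shown here, the change to compound 4 runs the other way, shortening the chain to a single methyl, and no measured step shows what shortening does. The two entries for compound 3 the several entries of compound 3 in this assay, 89.9 uM; 84.8 uM (2 entries) show how closely repeats of this assay sit. Compound 4 is therefore expected to stay near the limit, and the estimated step is a step that the limit leaves unreadable from compound 1 to compound 4, nothing beyond the scatter. Compound 4 is estimated at 120 uM, with a range from 50 uM to 300 uM, and most likely the assay again reports only a limit.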

Compound 4, half-maximal toxic concentration: 5.7 uM
The estimate for compound 4 lay 21-fold (1.32 log units) above the measured number; measured number outside the range, below it.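

Shortening the chain turned out to act in the same direction as lengthening it: in this assay the change to methyl gives an at least 17-fold lower number from compound 1 to compound 4 (1.24 log units; beyond the scatter). The other comparison, a 1.8-fold lower number from compound 2 to compound 4 (0.26 log units; within the scatter), separates neither compound, so compound 4, which has no carbamoyl group, and compound 2, which carries one at the end of a long chain, cannot be told apart, and the carbamoyl group alone does not keep the number high. The step out of compound 1 has no fixed size, as compound 1 stands at a limit: the limit of > 100 uM in this assay, at which 1 of the 4 values shown sits.

The compounds shown leave open whether the high number of compound 1 belongs to the carbamoyl group or to the length of its chain. A plain propyl chain, or a carboxylic acid in place of the carbamoyl group on the 2-carbamoylethyl chain, could separate the two.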